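Aryl swap on the shared core of compound 2

A few compounds are considered here, and "the series" means these few. Any claim that something is new, unique, unknown or untested is made for them only; others in the source may bear on it.

compound 1 `Cc1nnc(COc2cnn(C(C)(C)C)c(=O)c2Cl)o1`: > 300 ug/mL
compound 2 `COc1ccc(-c2nnc(COc3cnn(C(C)(C)C)c(=O)c3Cl)o2)cc1`: 17.7 ug/mL

In a functional assay on the whole organism for inhibition, with Mythimna separata as the target, with a stated time of 5 days (on this read-out higher numbers stand for an effect only at larger amounts of compound and lower numbers for an effect already at smaller amounts), compound 1 gives only a limit, > 300 ug/mL. Going by the values given here, compound 2 holds the only numeric value shown, 17.7 ug/mL. Among the compounds with values here, the one measured step, an at least 16-fold lower number from compound 1 to compound 2 (1.22 log units; beyond the scatter), shows that an aryl group here matters greatly; the size of that step is bounded by the limit of > 300 ug/mL in this assay, at which 1 of the 2 values shown sits. Compound 3 `CC(C)(C)n1ncc(OCc2nnc(-c3ccco3)o2)c(Cl)c1=O` carries furan-2-yl in place of 4-methoxyphenyl on an aromatic carbon. Furan-2-yl is a smaller aryl than 4-methoxyphenyl, so compound 3 is expected to keep much but not all of the gain of compound 2, a 2.3-fold higher number from compound 2 to compound 3 (0.35 log units; beyond the scatter). Compound 3 is estimated at 40 ug/mL, between 12 ug/mL and 140 ug/mL.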

Compound 3, half-maximal effective concentration: > 300 ug/mL
Compound 3 gave a limit, no number; the forecaster's own chance of this, stated with the estimate: 20%; at least 7.5-fold (0.87 log units) between middle value and limit.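

In this assay, an aromatic ring on this carbon is not enough by itself: furan-2-yl in place of 4-methoxyphenyl gives an at least 16-fold higher number from compound 2 to compound 3 (1.22 log units; beyond the scatter). The value of compound 3 is a limit, not a number, and the step from compound 1 to compound 3 cannot be read. Only the 4-methoxyphenyl group of compound 2 gives a numeric value so far, and the series is largely capped: the limit of > 300 ug/mL in this assay, at which 2 of the 3 values shown sit.

Open, from the compounds shown here alone, is whether the methoxy group or the six-membered ring carries the effect, which unsubstituted phenyl could separate. Also open, going by these compounds, is how thiophen-2-yl or pyridin-3-yl would read at this position.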